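The compounds below may be only part of what the source reports. "The series", "measured", "known", "first", "only" and "open" are said of these compounds alone.

Measured in a functional assay on the whole organism (strain BALB/c) for inhibition, with Mus musculus as the target, read by paw edema, with a stated time of 4 h, at a dose of 50 mg/kg by the oral route; a lower number here means less inhibition, a higher number more inhibition at the dose given (going by the name of the read-out):
- compound 1, `Cc1ccc(-n2c(-c3cc(-c4ccc(F)cc4F)ccc3O)n[nH]c2=S)cc1`: 51.6%
- compound 2, `CCn1c(-c2cc(-c3ccc(F)cc3F)ccc2O)n[nH]c1=S`: 46.2%

Of these two numbers, compound 2 stands lowest, with compound 1 nearest; the step of a number 5.4 percentage points lower from compound 1 to compound 2 (within the scatter) lies within the scatter of the measurement. Compound 3, `Oc1ccc(-c2ccc(F)cc2F)cc1-c1n[nH]c(=S)n1-c1ccccc1`, differs from compound 2 by phenyl in place of ethyl on an aromatic nitrogen. Going by the values given here, the one measured step that bears on this change, a number 5.4 percentage points lower from compound 1 to compound 2 (within the scatter), also exchanged the group on an aromatic nitrogen and stayed within the scatter, so for compound 3 the expected step is a number 3.8 percentage points higher from compound 2 to compound 3 (within the scatter), none beyond the scatter. Compound 3 is estimated at 50%, in a range from 38% to 62%.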

Compound 3, a percentage reported as inhibition, in the whole organism at one dose (the size of the read-out at that dose, not a potency): 36.3%
Compound 3: the middle estimate sits 13.7 percentage points above what was measured; measured number outside the range, below it.
By their numbers in this assay, from the lowest: compounds 3, 2 and 1 (each within the scatter of the next, the first and the last beyond it).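

In this assay, phenyl in place of ethyl on the aromatic nitrogen gives a number 9.9 percentage points lower from compound 2 to compound 3 (within the scatter), so a ring at this position cannot be told apart from a small chain. Hydrogen in place of methyl on an aromatic carbon gives a number 15.3 percentage points lower from compound 1 to compound 3 (beyond the scatter), which shows that this single methyl on the phenyl ring separates two compounds by a modest step. No measurement shown here explains that step. Going by these compounds, it remains open how a longer chain such as butyl on the nitrogen, or a chlorine or methoxy group on the phenyl ring, would read out.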